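The source may hold more compounds than are shown below. What is called first, only, known or untested is meant among the compounds shown, and "the series" means these compounds.

Measured compounds:
Compound 1, `Nc1ccccc1NC(=O)c1ccc(CSC(=S)N2CCN(Cc3ccccn3)CC2)cc1`, 61.4%
Compound 2, `Nc1ccccc1NC(=O)c1ccc(CSC(=S)N2CCc3ccccc32)cc1`, 67%
Compound 3, `CCN(Cc1ccncc1)C(=S)SCc1ccc(C(=O)Nc2ccccc2N)cc1`, 77.7%

All three were tested in a functional assay on HeLa cells (Homo sapiens) for antiproliferative activity, read by CCK-8 assay, with a stated time of 72 h, tested at 8 uM; on this read-out lower numbers stand for a weaker effect and higher numbers for a stronger effect at the one concentration tested. Compound 1 stands at the lowest of the three numbers: its gap to compound 2 lies within the usual scatter of repeated measurements, while its gap to compound 3 lies beyond that scatter.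

Compound 4, `Cc1ccc(N2CCN(C(=S)SCc3ccc(C(=O)Nc4ccccc4N)cc3)CC2)cc1`, has not yet been measured. It differs from compound 1 in a single place: 4-methylphenyl in place of (pyridin-2-yl)methyl on an amine nitrogen in a ring. Within the data shown here, the only measured step that changes one place at a time is a number 10.7 percentage points higher from compound 2 to compound 3 (beyond the scatter), and that exchange sits on a thiocarbonyl carbon, not on the amine nitrogen in the ring where compound 4 differs from compound 1. Among the measured compounds shown here, no measured step therefore bears directly on this exchange. With nothing to point in either direction, the reasonable expectation is a step that stays within the scatter: a number 1.6 percentage points higher from compound 1 to compound 4 (within the scatter) is the change expected here. Compound 4 is accordingly estimated to give 63% in this assay, with a likely range from 50% to 76%.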

Compound 4, a percentage reported as inhibition, at one concentration (the size of the read-out at that concentration, not a potency): 24%
For compound 4 the middle estimate is 39 percentage points above the measured one, outside the stated range (below it).
By their numbers in this assay, from the lowest: compound 4; then compounds 1 and 2 (each within the scatter of the next); then compound 3.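

In this assay the amine nitrogen in the ring proves sensitive to what it carries, since a number 37.4 percentage points lower from compound 1 to compound 4 (beyond the scatter) is a large step beyond the scatter. This happens even though 4-methylphenyl and (pyridin-2-yl)methyl hold the same number of heavy atoms and each brings one six-membered aromatic ring, so matching size by that count does not preserve the read-out here. The exchange alters several things at once, removing the ring nitrogen and its hydrogen-bond acceptor, removing the methylene link to the amine nitrogen and adding a methyl on the ring, and no measurement shown explains the step or assigns it to any one of these features.

The compounds shown leave open which of these differences matters, and a benzyl group or an unsubstituted phenyl group on the same nitrogen would help to separate them. They also leave open whether a pyridin-2-yl group attached directly to that nitrogen would give a number closer to that of compound 1 or to that of compound 4.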